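Same Benzyl Change, a Second Core, an Open Question

The source may report more compounds than this note shows. Statements on the series, on what has been measured and on what is new or still open speak of the compounds shown alone.

In a functional assay on L1210 cells (Mus musculus) for antiproliferative activity (on this read-out higher numbers stand for weaker inhibition and lower numbers for stronger inhibition), compound 1 `CSc1nc2sncc2n1[C@H]1C[C@H](O)[C@@H](CO)O1` gives 20000 nM. Compound 2 `OC[C@H]1O[C@@H](n2c(SCc3ccccc3)nc3sncc32)C[C@@H]1O` differs from it by phenyl in place of hydrogen on a saturated chain carbon bound to a sulfur, and in this assay compound 2 gives 2200 nM. That change produced a 9.1-fold lower number from compound 1 to compound 2 (0.96 log units; beyond the scatter).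

Compound 3 `CSc1nc2c(C)nsc2n1[C@@H]1O[C@H](CO)[C@@H](O)[C@H]1O` is built on a different core, and the difference between the two cores is not broken down here. In this assay compound 3 gives only a limit, > 100000 nM, which is a boundary of the measurement rather than a number. It sits at the limit of > 100000 nM in this assay, at which 1 of the 3 values shown sits.

Compound 4 `Cc1nsc2c1nc(SCc1ccccc1)n2[C@@H]1O[C@H](CO)[C@@H](O)[C@H]1O` has not been measured. It differs from compound 3 by phenyl in place of hydrogen on a saturated chain carbon bound to a sulfur, the same change that turned compound 1 into compound 2, at the same kind of place. If that change acts on the second core as it did on the first, compound 4 is expected to show a step of about an at least 2.5-fold lower number from compound 3 to compound 4 (0.39 log units; beyond the scatter) from compound 3, resting on the step from compound 1 to compound 2 of a 9.1-fold lower number from compound 1 to compound 2 (0.96 log units; beyond the scatter). Because compound 3 is known only as a limit, the starting point is uncertain, and compound 4 may itself fall beyond the reach of the assay. On this basis the estimate for compound 4 in this assay is 40000 nM, with a plausible span from 8000 nM to 200000 nM.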

Compound 4, half-maximal inhibitory concentration: > 100000 nM
Compound 4: no number, only a limit (the forecaster's own chance of this, stated with the estimate: 45%); middle value at least 2.5-fold (0.39 log units) from the limit.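

In this assay compound 4 gives > 100000 nM, which is a limit and not a number. Compound 3 gives > 100000 nM, also a limit, so no step between compound 3 and compound 4 can be read: the limit of > 100000 nM in this assay, at which 2 of the 4 values shown sit.

On these data alone, whether benzylsulfanyl in place of methylsulfanyl lowers the number on the core of compound 3, as it did on the core of compound 1, stays open.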